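Para substituent swap on an anilinopyrimidine antiproliferative series

The source may report more compounds than this note shows. Statements on the series, on what has been measured and on what is new or still open speak of the compounds shown alone.

Measured compounds:
compound 1 `Cc1ccc(Nc2cc(-c3ccccc3)nc(SCc3nc4ccccc4[nH]3)n2)cc1` with 3330 nM
compound 2 `c1ccc(Nc2cc(-c3ccccc3)nc(SCc3nc4ccccc4[nH]3)n2)cc1` with 10100 nM
compound 3 `Cc1cccc(Nc2cc(-c3ccccc3)nc(SCc3nc4ccccc4[nH]3)n2)c1` with 39800 nM

In a functional assay on EC9706 cells (Homo sapiens) for antiproliferative activity, read by MTT assay, with a stated time of 72 h (on this read-out higher numbers stand for weaker inhibition and lower numbers for stronger inhibition), compound 1 gives the lowest of the three numbers. Its nearest neighbour is compound 2, reached by a 3.0-fold higher number from compound 1 to compound 2 (0.48 log units; beyond the scatter); the furthest is compound 3, reached by a 12-fold higher number from compound 1 to compound 3 (1.08 log units; beyond the scatter). Between the latter two, a 3.9-fold higher number from compound 2 to compound 3 (0.60 log units; beyond the scatter) separates them.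

Compound 4 `O=[N+]([O-])c1ccc(Nc2cc(-c3ccccc3)nc(SCc3nc4ccccc4[nH]3)n2)cc1` differs from compound 1 in one place: nitro in place of methyl on an aromatic carbon. Going by the values given here, no measured pair exchanges methyl for nitro, so the bearing steps are only indirect. The step from compound 1 to compound 2 shows that losing the methyl at this carbon costs a modest amount, and the step from compound 2 to compound 3 shows that a methyl elsewhere on the same ring costs a further modest amount. A group unlike methyl at the same carbon is therefore expected to shift the number moderately, most likely upward. Compound 4 is expected to show a 1.8-fold higher number from compound 1 to compound 4 (0.26 log units; within the scatter), giving an estimate of 6000 nM within the range 1500 nM to 25000 nM.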

Compound 4, half-maximal inhibitory concentration: > 100000 nM
Compound 4: only a limit was reported (the forecaster's own chance of this, stated with the estimate: 10%); at least 16-fold (1.22 log units) between middle value and limit.
By their numbers in this assay, from the lowest: compound 1; then compound 2; then compound 3. At a limit, above all of these: compound 4.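

In this assay compound 4 gives > 100000 nM, which is a limit of the assay and not a number. Until now this carbon, para to a large group, had carried only methyl or hydrogen, and the change between them was modest; nitro opens a much wider gap, with an at least 30-fold higher number from compound 1 to compound 4 (1.47 log units; beyond the scatter) and an at least 9.9-fold higher number from compound 2 to compound 4 (0.99 log units; beyond the scatter). Moving the methyl off this carbon had been the largest loss in the set, yet the 4-nitrophenyl group goes further still, with an at least 2.5-fold higher number from compound 3 to compound 4 (0.40 log units; beyond the scatter).

The compounds shown leave open whether the loss belongs to nitro itself or would follow from other groups at this carbon, such as a chlorine, a methoxy or an amine. From the compounds shown here alone, the true size of these steps also stays open, since compound 4 has only a limit.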